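A Methoxy Swap Starting From the Assay Limit

A few compounds are considered here, and "the series" means these few. Any claim that something is new, unique, unknown or untested is made for them only; others in the source may bear on it.

Of the compounds shown here, two have so far been tested in an ADME assay on MCF7 cells (Homo sapiens) for cytotoxicity, with a stated time of 72 h; a higher number here means a weaker inhibitor, a lower number a stronger inhibitor. Compound 1 (`COc1ccccc1CNc1ncnc2c1ncn2C1CCCCO1`) gives > 100000 nM, which is a limit of the assay and not a number. Compound 2 (`Oc1cccc(CNc2ncnc3c2ncn3C2CCCO2)c1`) gives > 100000 nM, which is also a limit. Compound 2 therefore has no exact value, and the two results together stand as the limit of > 100000 nM in this assay, at which 2 of the 2 values shown sit.

Compound 3 (`COc1ccccc1CNc1ncnc2c1ncn2C1CCCO1`) has not yet been measured. It is reached from compound 2 by a single change, (2-methoxyphenyl in place of 3-hydroxyphenyl on a saturated chain carbon bound to a nitrogen on an aromatic ring), with 2-methoxyphenyl in place of 3-hydroxyphenyl on a saturated chain carbon bound to a nitrogen on an aromatic ring. For the measured compounds named here, no measured pair shows what a change of this kind does, so the size of the step cannot be read from the data. The expectation rests only on (the limit of > 100000 nM in this assay, at which 2 of the 2 values shown sit), and it is for no step beyond the usual scatter in this assay, in either direction. The estimated step is a number no higher from compound 2 to compound 3 (the limit leaves the size open). Compound 3 is expected at 100000 nM, with an estimated range of 50000 nM to 200000 nM, and will most likely be reported only as a limit.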

Compound 3, half-maximal inhibitory concentration: > 100000 nM
Compound 3 ended at the assay's limit; the forecaster's own chance of this, stated with the estimate: 85%; the middle value lies on the limit itself.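

For the compounds shown here, compound 3, like compound 1 and compound 2, stands at a limit of the assay, so no step to compound 3 from either of them can be read in this assay. The compounds shown leave open what either change does to the read-out and where any of the three would reach half-maximal inhibition: the limit of > 100000 nM in this assay, at which 3 of the 3 values shown sit.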